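Trimming the piperidine amide of compound 1 to an acetamide

The source may report more compounds than this note shows. Statements on the series, on what has been measured and on what is new or still open speak of the compounds shown alone.

Compound 1, `COc1ccc(-c2cnc(NC(=O)C3CCNCC3)n2C)cc1`, was tested in a toxicity assay on THP-1 cells (Homo sapiens) for inhibition (a lower number here means that less compound is tolerated, a higher number that more compound is tolerated), where compound 1 gives only a limit, > 100000 nM. Compound 2, `Cn1c(-c2ccc(C#N)cc2)cnc1NC(=O)c1ccc(F)cc1`, likewise gives only a limit in this assay, > 50000 nM. Within the data shown here, compound 1 thus sits at the top of what was examined (the limit of > 100000 nM in this assay, at which 1 of the 2 values shown sits), with no measured step to any neighbour. Compound 3, `COc1ccc(-c2cnc(NC(C)=O)n2C)cc1`, differs from compound 1 by one change: methyl in place of piperidin-4-yl on a carbonyl carbon. Among the measured compounds shown here, no measured pair shows what such a change does here. The step from compound 1 to compound 3 is expected to be a number no higher from compound 1 to compound 3 (the limit leaves the size open), nothing beyond the scatter. Compound 3 is therefore estimated at 100000 nM, between 30000 nM and 300000 nM, most likely again reported as a limit.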

Compound 3, half-maximal cytotoxic concentration: > 100000 nM
Compound 3: only a limit was reported (the forecaster's own chance of this, stated with the estimate: 80%); the middle value sits exactly at the limit.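

Among these compounds, compound 1 and compound 3 both rest on limits, and no step between them can be read. The compounds shown leave open where either would give a measured value in this assay, and whether methyl in place of piperidin-4-yl changes anything there.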